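The source may hold more compounds than are shown below. What is called first, only, known or untested is meant among the compounds shown, and "the series" means these compounds.

Working notes on the series.

Three compounds share one core and differ only in the length of the chain carrying the isothiocyanate. Compound 1 `CN(C)C(=O)c1cc2cnc(Nc3ccc(S(=O)(=O)NCCCCN=C=S)cc3)nc2n1C1CCCC1` gives 39.4% in a functional assay on A549 cells (Homo sapiens) for inhibition, read by CCK-8 assay, with a stated time of 72 h, tested at 1 uM; a higher number here means a stronger effect of the compound at the concentration tested, a lower number a weaker effect. Compound 2 `CN(C)C(=O)c1cc2cnc(Nc3ccc(S(=O)(=O)NCCCCCN=C=S)cc3)nc2n1C1CCCC1` gives 56.6% in this assay. Compound 3 `CN(C)C(=O)c1cc2cnc(Nc3ccc(S(=O)(=O)NCCCCCCN=C=S)cc3)nc2n1C1CCCC1` gives 49.5% in this assay.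

Compound 3 stands second highest of the three numbers: against compound 2 the gap is within the scatter, against compound 1 it is beyond it.

The measured steps are all of the same kind as the one now in question. a number 17.2 percentage points higher from compound 1 to compound 2 (beyond the scatter). a number 10.1 percentage points higher from compound 1 to compound 3 (beyond the scatter). a number 7.1 percentage points lower from compound 2 to compound 3 (within the scatter).

Compound 4 `CN(C)C(=O)c1cc2cnc(Nc3ccc(S(=O)(=O)NCCCCCCCN=C=S)cc3)nc2n1C1CCCC1` has not been measured in this assay. Relative to compound 3 the change is: a group of 4 heavy atoms (2 carbon, 1 nitrogen, 1 sulfur; no ring) in place of a group of 3 heavy atoms (1 carbon, 1 nitrogen, 1 sulfur; no ring), on a saturated chain carbon, six bonds along the chain from a sulfonamide nitrogen.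

The first two steps show a gain from compound 1, but the step from compound 2 to compound 3 of the same kind is flat. The bearing step on compound 4 is the last one, so no step beyond the scatter is expected, in either direction. The estimated step from compound 3 to compound 4 is a number 2.5 percentage points lower from compound 3 to compound 4 (within the scatter). Compound 4 is therefore expected to give about 47% in this assay, with the range 34% to 60%.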

Compound 4, a percentage reported as inhibition, at one concentration (the size of the read-out at that concentration, not a potency): 32.6%
Compound 4: the middle estimate sits 14.4 percentage points above what was measured; the measured number lies below the stated range.
By their numbers in this assay, from the lowest: compounds 4 and 1 (each within the scatter of the next); then compounds 3 and 2 (each within the scatter of the next).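

At this position, six bonds along the chain from a sulfonamide nitrogen, lengthening the chain brings the first loss beyond the scatter in this assay: a number 16.9 percentage points lower from compound 3 to compound 4 (beyond the scatter), and likewise a number 24 percentage points lower from compound 2 to compound 4 (beyond the scatter). The longest chain shown gives no gain over the shortest, with a number 6.8 percentage points lower from compound 1 to compound 4 (within the scatter), so compound 1 and compound 4 both sit beyond the scatter under compound 2 and compound 3, and the numbers rise and then fall along these four compounds rather than following chain length in one direction. The earlier compounds showed only gains and a flat step, whereas the same added chain carbon now has opposite outcomes depending on where along the chain it falls: the same change on two cores in this assay, a number 17.2 percentage points higher (beyond the scatter) from compound 1 to compound 2 and a number 16.9 percentage points lower (beyond the scatter) from compound 3 to compound 4, 34.1 percentage points apart, beyond the scatter of two such steps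

Going by these compounds, whether a still longer chain stays at this level or falls further remains open, and so does the part played by the isothiocyanate itself, which an amine or a carboxylic acid at the chain end would help to separate from chain length. The read-out is also the size of the effect at one concentration, so these differences speak only of a stronger or weaker effect at that concentration.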